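The source may report more compounds than this note shows. Statements on the series, on what has been measured and on what is new or still open speak of the compounds shown alone.

In a functional assay on DU-145 cells (Homo sapiens) for cytotoxicity, read by MTT assay (on this read-out higher numbers stand for weaker inhibition and lower numbers for stronger inhibition), compound 1 `COc1cccc(CSc2nnc([C@@H](C)c3ccc4cc(OC)ccc4c3)n2-c2ccc(Cl)cc2)c1` is known only through a limit, <= 400000 nM. Two close relatives do carry numbers: compound 2 `COc1ccc2cc([C@H](C)c3nnc(SCc4ccc(Cl)cc4)n3-c3ccc(Cl)cc3)ccc2c1` gives 109000 nM, and compound 3 `COc1ccc2cc([C@H](C)c3nnc(SCc4ccccc4)n3-c3ccc(Cl)cc3)ccc2c1` gives 35800 nM. Compound 4 `COc1cccc(CSc2nnc([C@@H](C)c3ccc4cc(OC)ccc4c3)n2-c2ccc(F)cc2)c1` keeps the core of compound 1 and alters a single substituent: fluoro in place of chloro on an aromatic carbon. This is fluoro in place of chloro on an aromatic carbon, 4-chlorophenyl to 4-fluorophenyl.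

Going by the values given here, no measured step makes this exchange. Both steps leaving compound 1 are unreadable: a step that the limit leaves unreadable from compound 1 to compound 2 and a step that the limit leaves unreadable from compound 1 to compound 3. Among the compounds with values here, the only readable step is a 3.0-fold lower number from compound 2 to compound 3 (0.48 log units; beyond the scatter), which removes a chloro at a different place in the molecule. That modest step gives no direction for compound 4, and a change of about that size or less is expected. The step expected in this assay is a step that the limit leaves unreadable from compound 1 to compound 4. The estimate is therefore placed near compound 3 at 35800 nM and compound 2 at 109000 nM, with a wide range. Compound 4 is expected at 70000 nM, with an estimated range from 18000 nM to 300000 nM.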

Compound 4, half-maximal inhibitory concentration: 19200 nM
Compound 4: middle estimate off by 3.6-fold (0.56 log units), on the high side; the measured number falls inside the stated range.
By their numbers in this assay, from the lowest: compounds 4 and 3 (each within the scatter of the next); then compound 2.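

No new step can be read from compound 1 to compound 4 in this assay, because compound 1 is known only through a limit: the limit of <= 400000 nM in this assay, at which 1 of the 4 values shown sits.

The compounds shown leave open what fluoro in place of chloro on an aromatic carbon does to the number when both partners carry measured values.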